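Bromo-fluorophenyl analogue of an inactive dichlorophenyl congener

This account rests on a few compounds, and the source may have more. Where it says the series, first, only, none or still open, it means among the compounds named here.

In a functional assay on Huh-7 cells (Homo sapiens) for cytotoxicity, read by CCK-8 assay, with a stated time of 72 h (on this read-out lower numbers stand for stronger inhibition and higher numbers for weaker inhibition), compound 3 `C=CCn1c(=O)/c(=C\c2ccc(Cl)c(Cl)c2)[nH]c(=O)/c1=C\c1ccccc1OC` is reported as "not active" (no number reported), with no number given, so it stands without a measured value. Its two congeners bear single substituents: compound 1 `C=CCn1c(=O)/c(=C\c2cccc(Cl)c2)[nH]c(=O)/c1=C\c1ccccc1OC` gives 8900 nM and compound 2 `C=CCn1c(=O)/c(=C\c2cccc(F)c2)[nH]c(=O)/c1=C\c1ccccc1OC` gives 27200 nM, with a 3.1-fold higher number from compound 1 to compound 2 (0.49 log units; beyond the scatter) separating them. The change to compound 4 `C=CCn1c(=O)/c(=C\c2cc(Br)ccc2F)[nH]c(=O)/c1=C\c1ccccc1OC` is 5-bromo-2-fluorophenyl in place of 3,4-dichlorophenyl on a double-bonded chain carbon bound to an aromatic carbon. Going by the values given here, no measured step matches this swap of two groups at once; the only comparable step is the fluoro for chloro exchange, which was modest. Compound 4 is therefore expected to show weak activity in this assay, with an estimated value near 30000 nM and a plausible range from 8000 nM to 120000 nM.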

Compound 4, half-maximal inhibitory concentration: "not active" (no number reported)
For compound 4 the study gives words and no number, so the estimate cannot be set against anything.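

In this assay compound 3 and compound 4 are both reported only in words, so no step can be read between them. From the compounds shown here alone, how the 3,4-dichlorophenyl and 5-bromo-2-fluorophenyl groups rank therefore stays open. No supporting evidence bears on this result.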